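The source may report more compounds than this note shows. Statements on the series, on what has been measured and on what is new or still open speak of the compounds shown alone.

Measured compounds:
- compound 1, `COc1cc(-c2nn(-c3cccc(NC(=O)Nc4ccc(Cl)c(Cl)c4)c3)cc2-c2ccncc2)ccc1Cl`: > 50000 nM
- compound 2, `COc1cc(-c2nn(-c3cccc(NC(=O)Nc4cccc(C(F)(F)F)c4)c3)cc2-c2ccncc2)ccc1Cl`: 12500 nM
- compound 3, `COc1cc(-c2nn(-c3cccc(NC(=O)Nc4ccc(Cl)c(C(F)(F)F)c4)c3)cc2-c2ccncc2)ccc1Cl`: 18300 nM

In a functional assay on Hs-578T cells (Homo sapiens) for inhibition, read by sulforhodamine B assay, with a stated time of 48 h (on this read-out lower numbers stand for stronger inhibition of growth and higher numbers for weaker inhibition of growth), compound 1 gives > 50000 nM, which is a limit of the assay rather than a number (the limit of > 50000 nM in this assay, at which 1 of the 3 values shown sits). Compound 2 gives 12500 nM and compound 3 gives 18300 nM. Compound 3 thus holds the higher of the two numbers that were actually obtained, with compound 2 its nearest neighbour at a gap within the scatter: a 1.5-fold higher number from compound 2 to compound 3 (0.17 log units; within the scatter).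

Compound 4, `COc1cc(-c2nn(-c3cccc(NC(=O)c4ccccc4)c3)cc2-c2ccncc2)ccc1Cl`, differs from compound 3 in one place: phenyl in place of (4-chloro-3-(trifluoromethyl)phenyl)amino on a carbonyl carbon. Among the compounds with values here, no measured step makes this same change. The measured steps alter the groups on the amide-type nitrogen or on an aromatic carbon, an at least 4.0-fold lower number from compound 1 to compound 2 (0.60 log units; beyond the scatter) and an at least 2.7-fold lower number from compound 1 to compound 3 (0.43 log units; beyond the scatter), both at least modest in size, whereas the change to compound 4 removes the whole (4-chloro-3-(trifluoromethyl)phenyl)amino group and leaves a phenyl on the carbonyl carbon. The step therefore lies outside what the measured steps directly show, and the expectation in this assay is uncertain in either direction. A modest step towards a higher number is expected, a 1.6-fold higher number from compound 3 to compound 4 (0.21 log units; within the scatter). Compound 4 is expected to give 30000 nM, between 8000 nM and 100000 nM.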

Compound 4, concentration for total growth inhibition: > 100000 nM
Compound 4 ended at the assay's limit (the forecaster's own chance of this, stated with the estimate: 40%); at least 3.3-fold (0.52 log units) between middle value and limit.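

Compound 4 gives > 100000 nM in this assay, which is a limit of the assay and not a number, and the step to it from compound 1, itself at a limit, cannot be read. Putting phenyl on the carbonyl carbon in place of (4-chloro-3-(trifluoromethyl)phenyl)amino brings an at least 5.4-fold higher number from compound 3 to compound 4 (0.73 log units; beyond the scatter), and putting it there in place of (3-(trifluoromethyl)phenyl)amino brings an at least 8.0-fold higher number from compound 2 to compound 4 (0.90 log units; beyond the scatter). The earlier steps shown here changed only the groups on the outer aromatic ring, whereas these two change the amino link on the carbonyl carbon itself, and they show that the measurable growth inhibition of compound 2 and compound 3 does not survive this replacement.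

This change removes the amino nitrogen with its hydrogen and the ring's chloro and trifluoromethyl groups all at once, so the compounds shown cannot say which of these losses matters. A plain phenylamino group on the carbonyl carbon, or a methylene group in place of the amino nitrogen with the 3-(trifluoromethyl)phenyl ring kept, would pull these parts apart.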